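The source may report more compounds than this note shows. Statements on the series, on what has been measured and on what is new or still open speak of the compounds shown alone.

Within the data shown here, in a physicochemical assay for solubility, in phosphate buffer, with a stated time of 24 h, at pH 7.4, tested at 200 uM (on this read-out lower numbers stand for lower solubility and higher numbers for higher solubility), compound 2 `N#Cc1ccc2ccc(C(=O)c3ccc(F)c(O)c3)nc2c1` gives 25000 nM as the only true number in this small set. Compound 1 `O=C(c1ccc(F)c(O)c1)c1ccc2cc(O)ccc2n1` sits at > 200000 nM which is a limit of the assay and not a number. Compound 3 `Oc1cc(Nc2cccc(-c3cccc(O)c3F)n2)ccc1F` sits at > 200000 nM which is likewise only a limit. So the limit of > 200000 nM in this assay, at which 2 of the 3 values shown sit, is what most of the set shows, and compound 2 is the one compound with a measured value to work from.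

In compound 4 `O=C(O)CNc1ccc2ccc(C(=O)c3ccc(F)c(O)c3)nc2c1` the shared core stays and (carboxymethyl)amino stands in place of cyano on an aromatic carbon (carboxymethyl)amino in place of cyano on an aromatic carbon with nothing else changed. Among the measured compounds shown here, no measured pair shows this change on its own, so any expectation here is rough. The estimated step of a 6.8-fold higher number from compound 2 to compound 4 (0.83 log units; beyond the scatter) is upward and beyond the usual scatter, and it may well reach the limit of the assay. For compound 4 the estimated value is 170000 nM with an expected range from 70000 nM to 200000 nM in this read-out.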

Compound 4, solubility: > 200000 nM
Compound 4: no number, only a limit; the forecaster's own chance of this, stated with the estimate: 60%; at least 1.1-fold (0.07 log units) between middle value and limit.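

Among these compounds, putting (carboxymethyl)amino in place of cyano on this aromatic carbon gives, in this assay, an at least 8.0-fold higher number from compound 2 to compound 4 (0.90 log units; beyond the scatter), the only step in this set between compounds that differ in one place. From the compounds shown here alone, the value of compound 4, > 200000 nM, is a limit of the assay and not a number, so the step gives only a minimum size and its full size remains unknown. Compound 4 therefore joins the larger part of the set: the limit of > 200000 nM in this assay, at which 3 of the 4 values shown sit.

The compounds shown do not tell which part of the (carboxymethyl)amino group goes with this step, as the whole group enters in one change. A plain amine on the same aromatic carbon, or a carboxylic acid on a longer chain there, would help to separate those parts.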